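A One-Carbon Longer Diamine Tail

The source may report more compounds than this note shows. Statements on the series, on what has been measured and on what is new or still open speak of the compounds shown alone.

Of the compounds shown here, three have so far been measured in a physicochemical assay, read by spectrophotometry, with a stated time of 10 min, tested at 0.1 mM, in the presence of a further agent that is not named here; on this read-out higher numbers stand for a stronger effect at the one concentration tested and lower numbers for a weaker effect. Compound 1 `NCC(N)CCCCNC(=O)c1cc(O)c(O)c(O)c1` gives 62%. Compound 2 `CC(C)(C)OC(=O)NCC(CCCCNC(=O)CCn1cccc(O)c1=O)NC(=O)OC(C)(C)C` gives 34.5% in this assay. Compound 3 `NCC(N)CC(=O)N1CCN(C(=O)CCn2cccc(O)c2=O)CC1` gives 30.7%, the lowest of the three numbers; its gap to compound 2 lies within the scatter, while compound 1 stands beyond the scatter above it. Compound 4 `NCC(N)CCC(=O)N1CCN(C(=O)CCn2cccc(O)c2=O)CC1` has not yet been measured. It differs from compound 3 in a single place: 2,3-diaminopropyl in place of 1,2-diaminoethyl on a saturated chain carbon bound to a carbonyl carbon. For the measured compounds named here, no measured pair shows what such a lengthening of the chain does in this assay, so the expected step is a number 1.3 percentage points higher from compound 3 to compound 4 (within the scatter), that is, none beyond the scatter. The estimate for compound 4 in this assay is 32%, with a range from 22% to 43%.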

Compound 4, a percentage reported as activity, at one concentration (the size of the read-out at that concentration, not a potency): 36%
Estimate against measurement, compound 4: 4 percentage points below; the measured number falls inside the stated range.
By their numbers in this assay, from the lowest: compounds 3, 2 and 4 (each within the scatter of the next); then compound 1.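

This first single-place pair shows that, in this assay, putting 2,3-diaminopropyl in place of 1,2-diaminoethyl on a saturated chain carbon bound to a carbonyl carbon gives a number 5.3 percentage points higher from compound 3 to compound 4 (within the scatter). At this position, then, the assay does not tell these two diamine chains apart. Nothing measured here offers an explanation for this result. From the compounds shown here alone, whether a carboxylic acid or a much longer chain at this place would give a step beyond the scatter stays open. Compound 1 differs from compound 4 in more than one place, so what separates their numbers also remains unresolved.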